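This account rests on a few compounds, and the source may have more. Where it says the series, first, only, none or still open, it means among the compounds named here.

In a functional assay on the whole organism for inhibition, with Mythimna separata as the target, with a stated time of 5 days (a lower number here means that less compound is needed, a higher number that more compound is needed for the effect), compound 2 `Cc1cccc(-c2nnc(COc3cnn(C(C)(C)C)c(=O)c3Cl)o2)c1` gives 116000 nM, the only numerical value among the two results shown. For compound 1 `Cc1cc(C)cc(-c2nnc(COc3cnn(C(C)(C)C)c(=O)c3Cl)o2)c1` this assay reports only a limit, > 299000 nM. The step of an at least 2.5-fold lower number from compound 1 to compound 2 (0.41 log units; beyond the scatter) therefore begins from a limit, namely (the limit of > 299000 nM in this assay, at which 1 of the 2 values shown sits), and shows that a change on the phenyl ring can move the number beyond the scatter.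

Compound 3 `CC(C)(C)n1ncc(OCc2nnc(-c3cc(F)c(Cl)cc3Cl)o2)c(Cl)c1=O` differs from compound 2 by 2,4-dichloro-5-fluorophenyl in place of 3-methylphenyl on an aromatic carbon. Among the measured compounds shown here, no measured step involves halogens on this ring; the only guidance is the step from compound 1 to compound 2, in which a methyl removed from the phenyl ring lowered the number at least modestly. The change to compound 3 is larger than that step, and its direction cannot be read from the two measured compounds. A modest lowering is taken as the most plausible outcome, with wide uncertainty, so that the step is expected to be a 1.9-fold lower number from compound 2 to compound 3 (0.29 log units; within the scatter). Compound 3 is therefore expected to give 60000 nM in this assay, estimated to lie between 15000 nM and 250000 nM.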

Compound 3, half-maximal effective concentration: 23100 nM
Compound 3: middle estimate off by 2.6-fold (0.41 log units), on the high side; the range from low to high includes it.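

The earlier compounds shown here showed only that removing a methyl from the phenyl ring can move the number, whereas here a phenyl ring carrying two chlorines and a fluorine, and no methyl, is accepted at this position in this assay. The exchange of 3-methylphenyl for 2,4-dichloro-5-fluorophenyl gives a 5.0-fold lower number from compound 2 to compound 3 (0.70 log units; beyond the scatter), so this aromatic carbon on the five-membered ring responds to a change of the whole aryl group and not only to the loss of a methyl. The exchange of 3,5-dimethylphenyl for the same halogenated group gives an at least 12-fold lower number from compound 1 to compound 3 (1.11 log units; beyond the scatter), a step that can be stated only as a bound, as it starts from a limit: the limit of > 299000 nM in this assay, at which 1 of the 3 values shown sits.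

Which of the two chlorines or the fluorine matters, and how much of the step comes from the loss of the methyl, stays open, as all of these changes fall within one exchange and the compounds shown do not separate them. Also open, from the compounds shown here alone, is how the number would respond to a methoxy group, an amine or a trifluoromethyl group on the phenyl ring.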